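The compounds below may be only part of what the source reports. "The series", "measured", "known", "first", "only" and "open" are said of these compounds alone.

Going by the values given here, compound 1 `Cc1nc(SCC(=O)Nc2nc(-c3ccc(Cl)cc3)cs2)n(Nc2ccccc2)c1C` is one of two compounds measured in a functional assay on UACC-257 cells (Homo sapiens) for antiproliferative activity, read by sulforhodamine B assay, with a stated time of 48 h; a higher number here means that more compound is tolerated, a lower number that less compound is tolerated. In this assay compound 1 gives > 100000 nM, which is a limit of the assay and not a number. Compound 2 `Cc1ccc(Nn2c(SCC(=O)Nc3nc(-c4ccccc4)cs3)nc(C)c2C)cc1` was examined in the same way. In this assay compound 2 gives > 100000 nM, again a limit. Compound 1 thus stands at the edge of what the assay reports, and the other value shown is also a limit, as the limit of > 100000 nM in this assay, at which 2 of the 2 values shown sit, records. Compound 3 `COc1ccc(Nn2c(SCC(=O)Nc3nc(-c4ccc(Cl)cc4)cs3)nc(C)c2C)cc1` has not yet been measured. It differs from compound 1 by methoxy in place of hydrogen on an aromatic carbon. No step between measured compounds is available, so no step size can be read from the data, and because the limit of > 100000 nM in this assay, at which 2 of the 2 values shown sit, places both shown values at the limit, no shift beyond the scatter is expected in this assay. Compound 3 is therefore expected to give 100000 nM (between 40000 nM and 300000 nM) in this assay. The expected step is a number no higher from compound 1 to compound 3 (the limit leaves the size open), none beyond the scatter.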

Compound 3, concentration lethal to 50% of the cells: > 100000 nM
Compound 3: no number, only a limit; the forecaster's own chance of this, stated with the estimate: 85%; the middle value sits exactly at the limit.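

In this assay compound 3 gives > 100000 nM, which is a limit of the assay and not a number. Going by these compounds alone, no step from compound 1 to compound 3 can therefore be read. The compounds shown leave open what effect methoxy in place of hydrogen has, and what actual number any of them would give in this assay.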